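The source may report more compounds than this note shows. Statements on the series, on what has been measured and on what is new or still open speak of the compounds shown alone.

Of the compounds shown here, two built on one shared core have been tested in an assay on HepG2 cells for agonist activity at Bile acid receptor (Homo sapiens), read by a luciferase reporter, with a stated time of 24 h; on this read-out higher numbers stand for an effect only at larger amounts of compound and lower numbers for an effect already at smaller amounts. Compound 1 `CCc1oc2ccccc2c1C(=O)c1ccc(OCc2cccc(C(=O)O)c2)cc1` gives 15600 nM in this assay. Compound 2 `CCc1oc2ccccc2c1C(=O)c1cc(Br)c(OCc2cccc(OCC(=O)O)c2)c(Br)c1` gives 17800 nM in this assay, and this number sits within the usual scatter of the value for compound 1, so the two compounds cannot be separated on this read-out. Compound 3 `CCc1oc2ccccc2c1C(=O)c1cc(Br)c(OCc2ccc(C(=O)O)cc2)c(Br)c1` has not yet been measured in this assay. It differs from compound 2 in one place: 4-carboxyphenyl in place of 3-(carboxymethoxy)phenyl on a saturated chain carbon bound to an oxygen on an aromatic ring. Within the data shown here, no measured pair isolates this particular change, so its effect is unknown. Compound 3 is expected to remain in the same weak region because compound 2 gives 17800 nM and compound 1 gives 15600 nM. The expected step of a 1.4-fold lower number from compound 2 to compound 3 (0.14 log units; within the scatter) is small and not beyond the scatter. Compound 3 is estimated at 13000 nM, with a range from 4000 nM to 45000 nM.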

Compound 3, half-maximal effective concentration: 10300 nM
The estimate for compound 3 lay 1.3-fold (0.10 log units) above the measured number; the measured number falls inside the stated range.
By their numbers in this assay, from the lowest: compounds 3, 1 and 2 (each within the scatter of the next).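

In this assay, 4-carboxyphenyl in place of 3-(carboxymethoxy)phenyl on a saturated chain carbon bound to an oxygen on an aromatic ring gives a 1.7-fold lower number from compound 2 to compound 3 (0.24 log units; within the scatter) and so does not separate the pair. Among these compounds, this is the first comparison that isolates a single change at this place, as compound 1 and compound 2 differ in more than one place. It shows that this one exchange, which leaves an aromatic ring of carbon only and a carboxylic acid in the group, produces no readable difference, and no other measurement here bears on this result. All the compounds shown carry a carboxylic acid in this group, so what an amine or a primary amide would do at this place remains open. From the compounds shown here alone, whether any other group at this place would give a clear difference also remains open.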